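A few compounds are considered here, and "the series" means these few. Any claim that something is new, unique, unknown or untested is made for them only; others in the source may bear on it.

In an assay for inhibition of Fatty-acid amide hydrolase 1 (Rattus norvegicus) (a higher number here means a weaker inhibitor, a lower number a stronger inhibitor), compound 1 `COC(=O)c1ccccc1CCCCCCC(=O)c1ncc(-c2ccccn2)o1` gives 1 nM, compound 2 `O=C(CCCCCCc1ccccc1Cl)c1ncc(-c2ccccn2)o1` gives 1.9 nM and compound 3 `CS(=O)(=O)c1ccccc1CCCCCCC(=O)c1ncc(-c2ccccn2)o1` gives 37 nM. Compound 2 thus holds the second highest of the three numbers: it is separated from compound 1 by a 1.9-fold higher number from compound 1 to compound 2 (0.28 log units; within the scatter), whereas a 19-fold higher number from compound 2 to compound 3 (1.29 log units; beyond the scatter) and a 37-fold higher number from compound 1 to compound 3 (1.57 log units; beyond the scatter) are both large. Compound 4 `CSc1cccc(CCCCCCC(=O)c2ncc(-c3ccccn3)o2)c1` differs from compound 2 in one place: 3-(methylsulfanyl)phenyl in place of 2-chlorophenyl on a saturated chain carbon, six bonds along the chain from a carbonyl carbon. Among the measured compounds shown here, no measured step covers this exact change; the nearest is a 19-fold higher number from compound 2 to compound 3 (1.29 log units; beyond the scatter), but that step introduced methylsulfonyl, not methylsulfanyl, and the ring pattern of compound 4 is otherwise untested. A weakening smaller than that step is expected, a 3.2-fold higher number from compound 2 to compound 4 (0.50 log units; beyond the scatter), so compound 4 is estimated at 6 nM in this assay, within 2 nM to 30 nM.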

Compound 4, inhibition constant: 4.2 nM
Compound 4: the middle estimate sits 1.4-fold (0.15 log units) above what was measured; measured number inside the range.
By their numbers in this assay, from the lowest: compounds 1 and 2 (each within the scatter of the next); then compound 4; then compound 3.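

Replacing 2-chlorophenyl with 3-(methylsulfanyl)phenyl gives a 2.2-fold higher number from compound 2 to compound 4 (0.34 log units; beyond the scatter) in this assay, a modest step beside the large 19-fold higher number from compound 2 to compound 3 (1.29 log units; beyond the scatter). Among the compounds shown here, the chain end therefore accepts a change of both the substituent and the ring pattern at a modest cost, which the earlier compounds, all sharing one ring pattern, did not show. Nothing available accounts for the size of this step.

Compound 4 changes the group and the ring pattern together, and the compounds shown do not separate the two. As far as these compounds go, how a carboxylic acid or an amine on this ring would read also remains open.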